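The source may report more compounds than this note shows. Statements on the series, on what has been measured and on what is new or still open speak of the compounds shown alone.

Measured compounds:
Compound 1, `Cc1cc(S(=O)(=O)/N=C(\N)N/N=C/C#Cc2ccccc2)c(SCc2ccccc2C(F)(F)F)cc1Cl`: 18000 nM
Compound 2, `C/C(C#Cc1ccccc1)=N\N/C(N)=N/S(=O)(=O)c1cc(C)c(Cl)cc1SCc1ccccc1C(F)(F)F`: 23000 nM

Both numbers come from a functional assay on HCT-116 cells (Homo sapiens) for antiproliferative activity, read by MTT assay, with a stated time of 72 h; on this read-out higher numbers stand for weaker inhibition and lower numbers for stronger inhibition. Compound 2 and compound 1 lie within the scatter of each other, as the step of a 1.3-fold higher number from compound 1 to compound 2 (0.11 log units; within the scatter) shows; the two values cannot be told apart.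

Compound 3, `C/C(C#Cc1ccccc1)=N\N/C(N)=N/S(=O)(=O)c1cc(C)c(Cl)cc1SCc1ccc(Cl)cc1`, has not yet been measured. It differs from compound 2 in one place: 4-chlorophenyl in place of 2-(trifluoromethyl)phenyl on a saturated chain carbon bound to a sulfur. Among the compounds with values here, the only measured step, a 1.3-fold higher number from compound 1 to compound 2 (0.11 log units; within the scatter), concerns a change on an amine nitrogen, a different part of the molecule, and so gives no direct guide to a change on the saturated chain carbon bound to a sulfur. Within the data shown here, with no step bearing on this position, the plainest expectation is a step of about the size of the scatter or smaller, in no particular direction.

The expected step from compound 2 to compound 3 is no change at the digits printed from compound 2 to compound 3 (within the scatter). Compound 3 is estimated at 23000 nM, with a range from 8000 nM to 65000 nM.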

Compound 3, half-maximal inhibitory concentration: 10000 nM
Compound 3: middle estimate off by 2.3-fold (0.36 log units), on the high side; the measured number falls inside the stated range.
By their numbers in this assay, from the lowest: compounds 3, 1 and 2 (each within the scatter of the next, the first and the last beyond it).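

In this assay, within the data shown here, the group on the saturated chain carbon bound to a sulfur is the first place where a change moves the number beyond the scatter: 4-chlorophenyl in place of 2-(trifluoromethyl)phenyl gives a 2.3-fold lower number from compound 2 to compound 3 (0.36 log units; beyond the scatter), whereas the change on the amine nitrogen stayed within it. The step is modest, but it shows that antiproliferative activity responds to this position, and the two groups differ both in their substituent and in where it stands on the phenyl ring, so neither difference can be credited alone. Nothing available here explains the step.

The compounds shown leave open whether the substituent or its location matters more, which 2-chlorophenyl or 4-(trifluoromethyl)phenyl would help separate. They also leave open how an unsubstituted phenyl, a 4-methoxyphenyl or a longer chain between the sulfur and the ring would behave.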